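A Fluoro-for-Methoxy Swap Carried onto a Bulkier Core

A few compounds are considered here, and "the series" means these few. Any claim that something is new, unique, unknown or untested is made for them only; others in the source may bear on it.

Compound 1 `COc1ccc2c(/C=C(\C#N)C(=O)c3c[nH]c4cc(OC)ccc34)c[nH]c2c1` and compound 2 `COc1ccc2c(C(=O)/C(C#N)=C/c3c[nH]c4cc(F)ccc34)c[nH]c2c1` share a core and differ in one place: fluoro in place of methoxy on an aromatic carbon. In a functional assay on A549 cells (Homo sapiens) for cytotoxicity, read by WST assay, with a stated time of 48 h (on this read-out lower numbers stand for stronger inhibition and higher numbers for weaker inhibition), compound 1 gives 1700 nM, while compound 2 gives 800 nM. The change therefore produced a 2.1-fold lower number from compound 1 to compound 2 (0.33 log units; beyond the scatter).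

Compound 3 `COc1ccc(Cn2cc(/C=C(\C#N)C(=O)c3c[nH]c4cc(OC)ccc34)c3ccccc32)cc1` carries a different core; how its core differs from that of compound 1 is not broken down here. In this assay compound 3 gives 28900 nM, the highest number of the three measured compounds, so it is the weakest inhibitor among them, well apart from both compound 1 and compound 2.

Compound 4 `COc1ccc(Cn2cc(/C=C(\C#N)C(=O)c3c[nH]c4cc(F)ccc34)c3ccccc32)cc1` has not yet been measured. It differs from compound 3 in exactly one place: fluoro in place of methoxy on an aromatic carbon. The place of this change is described in the same words as for the step from compound 1 to compound 2, so it is the same change, now made on the core of compound 3.

The expected step is a 2.1-fold lower number from compound 3 to compound 4 (0.31 log units; beyond the scatter), resting on the fact that the same change gave a 2.1-fold lower number from compound 1 to compound 2 (0.33 log units; beyond the scatter) on the smaller core. Whether a change measured on one core carries over unchanged to another is uncertain, so the range around the estimate is kept wide. In this assay compound 4 is expected to give 14000 nM, with a plausible span from 6000 nM to 35000 nM.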

Compound 4, half-maximal inhibitory concentration: 36300 nM
Compound 4: the middle estimate sits 2.6-fold (0.41 log units) below what was measured; measured number above the stated range.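

On the core of compound 3, fluoro in place of methoxy leaves no difference that can be told apart from ordinary scatter in this assay: the swap gives a 1.3-fold higher number from compound 3 to compound 4 (0.10 log units; within the scatter). Set beside the step on the core of compound 1, this shows that the change does not carry over unchanged from one core to the other, so the gain seen on that core cannot be assumed on the core of compound 3: the same change on two cores in this assay, a 2.1-fold lower number (0.33 log units; beyond the scatter) from compound 1 to compound 2 and a 1.3-fold higher number (0.10 log units; within the scatter) from compound 3 to compound 4, 2.7-fold (0.43 log units) apart, beyond the scatter of two such steps

Within the data shown here, this does not show why the two cores respond differently, nor that the swap does harm on the core of compound 3, and with only two pairs in a single assay it supports no general rule for the series.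

The compounds shown leave open how another group on the same aromatic carbon, such as chloro, methyl or an amine, would behave on each of the two cores, and so whether the difference is particular to fluoro. They also leave open whether a core carrying a plain methyl group where compound 3 differs from compound 1 would respond to the swap like the core of compound 1 or like that of compound 3.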